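Amide aryl swap on a shared quinoline-free core, compound 4 expected

The source may report more compounds than this note shows. Statements on the series, on what has been measured and on what is new or still open speak of the compounds shown alone.

Measured so far:
Compound 1 `CCN1CCN(c2cc(C)c3cc(NC(=O)c4cccnc4)ccc3n2)CC1` — 26600 nM
Compound 2 `Cc1cc(N2CCCC2)nc2ccc(NC(=O)c3ccc(Cl)c(Cl)c3)cc12` — 26300 nM
Compound 3 `CCN(CC)c1cc(C)c2cc(NC(=O)c3ccc(Cl)c(Cl)c3)ccc2n1` — > 50000 nM (a limit)

In a functional assay on MCF7 cells (Homo sapiens) for antiproliferative activity, read by MTT assay, with a stated time of 72 h (a lower number here means a stronger inhibitor, a higher number a weaker inhibitor), compound 1 gives 26600 nM. Compound 2, which carries a different amine and a different aryl amide on the same core, gives 26300 nM in this assay, so compound 1 and compound 2 sit within the scatter of each other, and no order between them can be read. Compound 3 is reported in this assay only as a limit, > 50000 nM (the limit of > 50000 nM in this assay, at which 1 of the 3 values shown sits). Going by the values given here, the one step that is fully counted, an at least 1.9-fold higher number from compound 2 to compound 3 (0.27 log units; that floor lies within the scatter), exchanges the amine on the core; its floor lies within the scatter.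

Compound 4 `CCc1ccc(C(=O)Nc2ccc3nc(N4CCN(CC)CC4)cc(C)c3c2)cc1` differs from compound 1 at the amide end: 4-ethylphenyl in place of pyridin-3-yl on a carbonyl carbon. Among the compounds with values here, no measured step touches this position, so nothing in the data sets the size or direction of the change. Within the data shown here, because compound 1 gives 26600 nM and no step speaks to the amide aryl, compound 4 is expected to land near compound 1, with a 1.1-fold lower number from compound 1 to compound 4 (0.03 log units; within the scatter) as the estimated step. For compound 4 the estimate in this assay is 25000 nM, with a range from 8000 nM to 60000 nM.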

Compound 4, half-maximal inhibitory concentration: 3060 nM
Compound 4: middle estimate off by 8.2-fold (0.91 log units), on the high side; the measured number lies below the stated range.
By their numbers in this assay, from the lowest: compound 4; then compounds 2 and 1 (each within the scatter of the next). At a limit, above all of these: compound 3.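

In this assay, going by these compounds alone, the amide end proves to be a place where the number can move: putting 4-ethylphenyl in place of pyridin-3-yl on the carbonyl carbon gives an 8.7-fold lower number from compound 1 to compound 4 (0.94 log units; beyond the scatter) and is the first step in this set that lies beyond the scatter. Within the data shown here, the only earlier step exchanged the amine on the core and had a floor within the scatter, so it gave no sign of what the amide aryl could do. The exchange removes the ring nitrogen and its hydrogen-bond acceptor and adds the ethyl in a single step, and nothing among the data shown explains the drop in the number.

Among these compounds, the single step cannot separate the loss of the ring nitrogen from the gain of the ethyl, and a plain phenyl or a pyridin-3-yl carrying an ethyl would be needed to divide the two. Also open, on these data alone, are whether a longer chain such as propyl or butyl, or a methoxy in place of the ethyl, would move the number further, and whether the same exchange holds with pyrrolidin-1-yl or diethylamino on the core.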